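The compounds below may be only part of what the source reports. "The series", "measured", "known", "first", "only" and "open" are said of these compounds alone.

The account follows two measured compounds and one awaiting measurement in a functional assay on U-251 cells (Homo sapiens) for inhibition, read by sulforhodamine B assay, with a stated time of 48 h; on this read-out lower numbers stand for stronger inhibition of growth and higher numbers for weaker inhibition of growth. Compound 1 `COc1ccc(-c2ccc(-c3ccc(C(=N)N)o3)o2)cc1` gives 1740 nM in this assay. Compound 2 `N=C(N)c1ccc(-c2ccc(-c3cncc4ccccc34)s2)s1` gives 1720 nM in this assay. Where compound 1 stands on the numbers shown is therefore simple: its value and that of compound 2 lie within the scatter of each other, so neither can be placed above the other, and the two are best read as equivalent on this read-out.

Compound 3 `N=C(N)c1ccc(-c2ccc(-c3ccccc3)o2)o1` has not yet been measured in this assay. It differs from compound 1 in one place: hydrogen in place of methoxy on an aromatic carbon. Within the data shown here, no pair of measured compounds that differs in a single place is available, so the data offer no direct guide to how large such a step tends to be. Compound 3 is expected to give about 2500 nM in this assay, with a likely range from 900 nM to 7000 nM. The step of a 1.4-fold higher number from compound 1 to compound 3 (0.16 log units; within the scatter) is expected to be small, leaning toward weaker inhibition of growth, and may well stay within the scatter.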

Compound 3, concentration for 50% growth inhibition: 2220 nM
Estimate against measurement, compound 3: 1.1-fold (0.05 log units) above; measured number inside the range.
By their numbers in this assay, from the lowest: compounds 2, 1 and 3 (each within the scatter of the next).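

Among these compounds, the first single-place step in this set shows that, in this assay, hydrogen in place of methoxy on an aromatic carbon of the six-membered aromatic ring, para to a large group, gives a 1.3-fold higher number from compound 1 to compound 3 (0.11 log units; within the scatter). The two earlier compounds could not show this, since they differ in more than one place and their closely matching values said nothing about any single group. The methoxy group can therefore be exchanged for hydrogen at this place without a change that can be told from the scatter of this read-out, although no measured information is available here to explain that result.

The compounds shown leave open whether a different group at this place, such as a hydroxyl, an amine, a carboxylic acid or a longer alkoxy chain, would produce a step beyond the scatter. Among the compounds shown here, they also leave open whether the exchange of methoxy for hydrogen would read the same way on a core other than the one shared by compound 1 and compound 3.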